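A Second Ring Nitrogen on the Amine Substituent

The compounds below may be only part of what the source reports. "The series", "measured", "known", "first", "only" and "open" are said of these compounds alone.

Among the compounds with values here, compound 2 `Cc1cccc2sc(NC(=O)CCN3CCN(c4ccccn4)CC3)nc12` gives 1000 nM in an assay on membranes from brain for displacement of a labelled ligand from Sigma non-opioid intracellular receptor 1 (Cavia porcellus), read by scintillation counting, with a stated time of 120 min (a lower number here means a stronger inhibitor, a higher number a weaker inhibitor), the highest of the two numbers measured so far. Its nearest neighbour, compound 1 `Cc1cccc2sc(NC(=O)CCN3CCN(C(C)(C)C)CC3)nc12`, gives 147 nM in this assay, and the move between them is a 6.8-fold higher number from compound 1 to compound 2 (0.83 log units; beyond the scatter), which came with pyridin-2-yl in place of tert-butyl on an amine nitrogen in a ring. Compound 3 `Cc1cccc2sc(NC(=O)CCN3CCN(c4ncccn4)CC3)nc12` has not yet been measured. Its change from compound 2 is pyrimidin-2-yl in place of pyridin-2-yl on an amine nitrogen in a ring. Within the data shown here, no measured step compares these two aromatic groups directly; the only step available, a 6.8-fold higher number from compound 1 to compound 2 (0.83 log units; beyond the scatter), exchanged an alkyl group for an aromatic one and bears on the present change only loosely. Among the measured compounds shown here, since the new group keeps a six-membered aromatic ring on the same nitrogen and the one comparable step moved the number up, compound 3 is expected to show a 1.5-fold higher number from compound 2 to compound 3 (0.18 log units; within the scatter), at most a small step upward and possibly none beyond the scatter. The estimate for compound 3 in this assay is 1500 nM, within a range from 500 nM to 5000 nM.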

Compound 3, inhibition constant: 505 nM
The estimate for compound 3 lay 3.0-fold (0.47 log units) above the measured number; the range from low to high includes it.
By their numbers in this assay, from the lowest: compound 1; then compounds 3 and 2 (each within the scatter of the next).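

In this assay, the second ring nitrogen of pyrimidin-2-yl gives a 2.0-fold lower number from compound 2 to compound 3 (0.30 log units; within the scatter) and so does not separate it from pyridin-2-yl at this position, even though the count of hydrogen-bond acceptors in the group differs. The replacement of tert-butyl by an aromatic ring now has a second example, with a 3.4-fold higher number from compound 1 to compound 3 (0.54 log units; beyond the scatter) beyond the scatter, so the distance from compound 1 is not confined to pyridin-2-yl, and compound 1 is the strongest inhibitor of the three. Nothing measured here explains either the gap from tert-butyl or the absence of a clear difference between the two aromatic groups.

From the compounds shown here alone, it remains open whether a plain phenyl ring, with no ring nitrogen, or a smaller alkyl group such as methyl on the same amine nitrogen would read with compound 1 or with compound 2 and compound 3. Also open, going by these compounds, is whether a longer chain on the amide carbonyl would alter the number while tert-butyl or pyrimidin-2-yl stays in place.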